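Fluoro in Place of Hydrogen on the Phenyl of Compound 1

A few compounds are considered here, and "the series" means these few. Any claim that something is new, unique, unknown or untested is made for them only; others in the source may bear on it.

Compound 1 `COc1cc(-c2ncnn2-c2ccccc2)cc(OC)c1OC`: > 10000 nM
Compound 2 `COc1cc(-n2ncnc2-c2ccc(C)cc2)cc(OC)c1OC`: 250 nM
Compound 3 `COc1ccc(-c2ncnn2-c2cc(OC)c(OC)c(OC)c2)cc1`: 280 nM

In a functional assay on HeLa cells (Homo sapiens) for antiproliferative activity, read by MTT assay, with a stated time of 72 h (a lower number here means a stronger inhibitor, a higher number a weaker inhibitor), compound 1 gives only a limit, > 10000 nM, at which one of the three values sits (the limit of > 10000 nM in this assay, at which 1 of the 3 values shown sits). Compound 2 gives 250 nM and compound 3 gives 280 nM; the measured step of a 1.1-fold higher number from compound 2 to compound 3 (0.05 log units; within the scatter) lies within the scatter. Compound 4 `COc1cc(-c2ncnn2-c2ccc(F)cc2)cc(OC)c1OC` differs from compound 1 by fluoro in place of hydrogen on an aromatic carbon. Among the compounds with values here, no measured step covers this change, so the expectation rests on compound 1 alone, and the direction is open. For compound 4 a step of an at least 2.0-fold lower number from compound 1 to compound 4 (0.30 log units; that floor lies within the scatter) is estimated, leaving compound 4 near the limit with 5000 nM, expected between 800 nM and 10000 nM.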

Compound 4, half-maximal inhibitory concentration: > 10000 nM
Compound 4: a limit, no number (the forecaster's own chance of this, stated with the estimate: 45%); middle value at least 2.0-fold (0.30 log units) away from the limit.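

In this assay compound 4 gives > 10000 nM, a limit and not a number, as compound 1 does, so no step between compound 1 and compound 4 can be read: the limit of > 10000 nM in this assay, at which 2 of the 4 values shown sit.

The compounds shown leave open whether fluoro in place of hydrogen changes the activity of this series at all.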